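Ortho methyl in place of para isopropyl on the aryl

The compounds below may be only part of what the source reports. "The series", "measured", "known", "first", "only" and "open" are said of these compounds alone.

Measured in a functional assay on KBVIN cells (Homo sapiens) for antiproliferative activity, read by sulforhodamine B assay, with a stated time of 3 days (on this read-out lower numbers stand for an effect already at smaller amounts and higher numbers for an effect only at larger amounts of compound), so far:
compound 1, `CCC1=C(O)c2c(oc(-c3ccc(C(C)C)cc3)cc2=O)C(CC)(CC)C1=O`, 1.08 uM;
compound 2, `CCC1=C(O)c2c(oc(-c3cccc(C(F)(F)F)c3)cc2=O)C(CC)(CC)C1=O`, 5.42 uM;
compound 3, `CCC1=C(O)c2c(oc(-c3cccc(OC(F)(F)F)c3)cc2=O)C(CC)(CC)C1=O`, 9.95 uM.

Compound 1 gives the lowest number of the three in this assay: compound 2 lies well beyond the scatter above it, and compound 3 further still. Going by the values given here, the only single-point step among the measured compounds, a 1.8-fold higher number from compound 2 to compound 3 (0.26 log units; within the scatter), concerns two substituents that both sit on the same aryl ring and stays within the scatter.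

Compound 4, `CCC1=C(O)c2c(oc(-c3ccccc3C)cc2=O)C(CC)(CC)C1=O`, differs from compound 1 by 2-methylphenyl in place of 4-isopropylphenyl on an aromatic carbon. The change sits on an aromatic carbon next to the ring oxygen of the shared core. Among the compounds with values here, no measured step bears on this change directly, since the step from compound 2 to compound 3 swaps one group for another at a different aryl position. What the data do show is that every departure from the aryl group of compound 1 so far moved the number upward. A moderate rise is therefore expected, estimated as a 2.8-fold higher number from compound 1 to compound 4 (0.44 log units; beyond the scatter), with compound 4 expected at 3 uM within a range of 1 uM to 10 uM.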

Compound 4, concentration for half-maximal effect: 2.41 uM
Compound 4: middle estimate off by 1.2-fold (0.10 log units), on the high side, within the range that was stated.
By their numbers in this assay, from the lowest: compound 1; then compound 4; then compounds 2 and 3 (each within the scatter of the next).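

In this assay the exchange of 4-isopropylphenyl for 2-methylphenyl on the aromatic carbon next to the ring oxygen gives a 2.2-fold higher number from compound 1 to compound 4 (0.35 log units; beyond the scatter) and so counts as a modest step. It is the first step among these compounds to lie beyond the scatter, and it shows that the number responds to the aryl group at this position even when both groups are all-carbon, with no hydrogen-bond donors or acceptors. No measurement offered here gives a reason for this step.

The alkyl group changes in both size and place in this single step, so the two contributions cannot be separated. Also open, as far as these compounds go, is how the number would respond to an aryl group carrying an amine or a carboxylic acid at this position.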